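A few compounds are considered here, and "the series" means these few. Any claim that something is new, unique, unknown or untested is made for them only; others in the source may bear on it.

Compound 1 `Nc1nc(-c2ccccc2)cc(-c2ccc(Cl)cc2)c1C(=O)Nc1ccccc1` and compound 2 `O=C(Nc1ccccc1)c1c(-c2ccc(Cl)cc2)cc(-c2ccccc2)nc1Nc1ccc(Cl)cc1` share one core and differ in a single place, where a 4-chlorophenyl stands in place of hydrogen on a nitrogen on an aromatic ring. In a functional assay on RPMI18226 cells (Homo sapiens) for antiproliferative activity, read by sulforhodamine B assay, with a stated time of 48 h, tested at 10 uM (a lower number here means less inhibition, a higher number more inhibition at the concentration tested (going by the name of the read-out)), compound 1 gives 46%, and in this assay compound 2 gives 53%. The step between them, a number 7 percentage points higher from compound 1 to compound 2 (within the scatter), lies within the scatter, so the two numbers cannot be told apart. Of the two numbers, that of compound 2 is the highest, with compound 1 nearest and within the scatter of it. Compound 3 `COc1ccc(Nc2nc(-c3ccccc3)cc(-c3ccc(Cl)cc3)c2C(=O)Nc2ccccc2)cc1` has not yet been measured in this assay. It differs from compound 2 in one place: methoxy in place of chloro on an aromatic carbon. Within the data shown here, no measured step exchanges chloro for methoxy, so none bears directly on this change; the only step at hand, a number 7 percentage points higher from compound 1 to compound 2 (within the scatter), concerns another part of the molecule and was itself within the scatter. One therefore expects no step beyond the scatter in this assay, the estimated change being a number 3 percentage points lower from compound 2 to compound 3 (within the scatter). Compound 3 is thus expected to give 50% in this assay, with a range from 30% to 70%.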

Compound 3, a percentage reported as inhibition, at one concentration (the size of the read-out at that concentration, not a potency): 30%
Beside the measured number, compound 3's estimate is 20 percentage points above it, within the range that was stated.
By their numbers in this assay, from the lowest: compound 3; then compounds 1 and 2 (each within the scatter of the next).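

In this assay, among these compounds, the exchange of chloro for methoxy on this aromatic carbon gives a number 23 percentage points lower from compound 2 to compound 3 (beyond the scatter), the first step to lie beyond the scatter, so what stands at this position does matter to the read-out. The earlier pair alone could have suggested that a substituted phenyl on the nitrogen changes little, yet 4-methoxyphenyl in place of the hydrogen gives a number 16 percentage points lower from compound 1 to compound 3 (beyond the scatter), whereas the step to the 4-chlorophenyl compound stayed within the scatter; the outcome thus depends on the particular group on that phenyl and not merely on a phenyl being present. Nothing available accounts for this difference between chloro and methoxy.

As far as these compounds go, with only these two groups at the position, it remains open whether the lower number in compound 3 reflects the loss of chloro or the arrival of methoxy, and a plain hydrogen, a fluoro, a hydroxy or a dimethylamino group there would help to separate the two. Each number also comes from a single concentration, so how the compounds compare in potency remains undecided.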